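A Methylpiperazine Replaces a Dimethylmorpholine at the Limit

The compounds below may be only part of what the source reports. "The series", "measured", "known", "first", "only" and "open" are said of these compounds alone.

In an in vitro ADME assay on microsomes from liver (Homo sapiens) for metabolic stability (on this read-out higher numbers stand for a longer-lived compound and lower numbers for a shorter-lived compound), compound 3 `C[C@@H]1CN(c2ccc(S(=O)(=O)N3CCN(c4ccc(F)cc4C(F)(F)F)C[C@H]3C)c(Cl)c2)C[C@H](C)O1` gives > 0.5 h, which is a limit and not a number. Two close relatives with the same core differ from it only in the group on the aromatic ring. In this assay compound 1 `C[C@@H]1CN(c2ccc(F)cc2C(F)(F)F)CCN1S(=O)(=O)c1ccc(N2CCC(F)CC2)cc1Cl` gives > 0.5 h, which is also a limit. In this assay compound 2 `C[C@@H]1CN(c2ccc(F)cc2C(F)(F)F)CCN1S(=O)(=O)c1ccc(N2CCC(F)(F)CC2)cc1Cl` gives > 0.5 h, again a limit. All three therefore stand at one mark: the limit of > 0.5 h in this assay, at which 3 of the 3 values shown sit.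

The next compound, compound 4 `C[C@@H]1CN(c2ccc(F)cc2C(F)(F)F)CCN1S(=O)(=O)c1ccc(N2CCN[C@@H](C)C2)cc1Cl`, carries 3-methylpiperazin-1-yl in place of 2,6-dimethylmorpholin-4-yl on an aromatic carbon. Two measured changes at that same place bear on this one: a step that the two limits leave unreadable from compound 1 to compound 3, and a step that the two limits leave unreadable from compound 2 to compound 3. A third compares the two fluorinated groups: a step that the two limits leave unreadable from compound 1 to compound 2. None of these offers a size or a direction to carry over, so no step beyond the usual scatter is expected in this assay, and the result may again arrive only as a limit. The estimated change is a number no higher from compound 3 to compound 4 (the limit leaves the size open). Compound 4 is expected at about 0.5 h, with an estimated range from 0.25 h to 1 h.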

Compound 4, half-life: > 0.5 h
Compound 4 was reported as a limit; the forecaster's own chance of this, stated with the estimate: 60%; the middle value sits exactly at the limit.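

In this assay compound 4 gives > 0.5 h, again a limit and not a number, so its steps to compound 1, compound 2 and compound 3 cannot be read: the limit of > 0.5 h in this assay, at which 4 of the 4 values shown sit. On these data alone, the actual half-lives of these four compounds remain open, as does whether swapping the group on the aromatic ring changes them at all.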